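Solubility notes: benzyl substituent variation on the shared core

This account rests on a few compounds, and the source may have more. Where it says the series, first, only, none or still open, it means among the compounds named here.

Measured so far:
compound 1, `CNC(=O)c1cc(C(=O)NC2CCC2)cn(Cc2ccccc2)c1=O`: 24 ug/mL
compound 2, `CNC(=O)c1cc(C(=O)NC2CC2)cn(Cc2ccc(OC)cc2)c1=O`: 263 ug/mL

In a physicochemical assay for solubility, read by HPLC, in simulated intestinal fluid, with a stated time of 16 h, tested at 125 ug/mL (on this read-out higher numbers stand for higher solubility and lower numbers for lower solubility), compound 2 gives 263 ug/mL, the highest of the two numbers. Its nearest neighbour is compound 1, which gives 24 ug/mL in this assay, a gap described as beyond the scatter. The two compounds differ in more than one place, so the gap is not assigned to any single change.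

Compound 3, `CNC(=O)c1cc(C(=O)NC2CC2)cn(Cc2cccc3[nH]ncc23)c1=O`, has not yet been measured in this assay. It differs from compound 2 in one place: 1H-indazol-4-yl in place of 4-methoxyphenyl on a saturated chain carbon bound to an aromatic nitrogen. Within the data shown here, no measured pair separates these two groups, so the size of the step is open. Compound 3 is expected to sit somewhat below compound 2, with the step of a 2.4-fold lower number from compound 2 to compound 3 (0.38 log units; beyond the scatter) estimated as modest and possibly within the scatter. Compound 3 is expected to give about 110 ug/mL, within 25 ug/mL to 400 ug/mL.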

Compound 3, solubility: 4 ug/mL
For compound 3 the middle estimate is 28-fold (1.44 log units) above the measured one; measured number below the stated range.
By their numbers in this assay, from the lowest: compound 3; then compound 1; then compound 2.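

In this assay, the group on a saturated chain carbon bound to an aromatic nitrogen now has its first comparison differing in one place: 1H-indazol-4-yl in place of 4-methoxyphenyl gives a 66-fold lower number from compound 2 to compound 3 (1.82 log units; beyond the scatter) on the shared core. The read-out is therefore not indifferent to which aromatic group stands at this place, even though neither group carries a net charge. Nothing measured here bears on the origin of this step.

The compounds shown leave open whether the low number goes with the added five-membered aromatic ring or with the hydrogen-bond donor that 1H-indazol-4-yl brings. Also open, going by these compounds, is how a group carrying an amine or a carboxylic acid would read at this place on the shared core.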